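A few compounds are considered here, and "the series" means these few. Any claim that something is new, unique, unknown or untested is made for them only; others in the source may bear on it.

Compound 1 `CC(CNCC1CC1)Oc1cccc2ccc(N)nc12` carries a cyclopropylmethyl group on its amine nitrogen. Going by the values given here, in a functional assay on IMR-32 cells with melanin-concentrating hormone receptor 1 (Homo sapiens) as the target, read by fluorescence (on this read-out lower numbers stand for stronger inhibition and higher numbers for weaker inhibition), compound 1 gives 460 nM, the second highest of the three numbers measured so far. Compound 2 `CC(CNC1CC1)Oc1cccc2ccc(N)nc12`, with cyclopropyl on the same nitrogen, gives 580 nM in this assay, and the step of a 1.3-fold higher number from compound 1 to compound 2 (0.10 log units; within the scatter) stays within the scatter. Compound 3 `CC(CNC1CCCC1)Oc1cccc2ccc(N)nc12`, with cyclopentyl there, gives 30 nM in this assay; the step of a 15-fold lower number from compound 1 to compound 3 (1.19 log units; beyond the scatter) and the step of a 19-fold lower number from compound 2 to compound 3 (1.29 log units; beyond the scatter) are both large. Compound 4 `CC(CNCc1ccsc1)Oc1cccc2ccc(N)nc12` differs from compound 1 in one place: thiophen-3-yl in place of cyclopropyl on a saturated chain carbon bound to an amine nitrogen. Among the compounds with values here, no measured step replaces a saturated ring with an aromatic one, so none bears directly on this change. The measured steps show only that moving from cyclopropylmethyl to cyclopropyl changed little, while cyclopentyl brought a large drop in the number. A five-membered aromatic ring entering at the same chain carbon is therefore expected to lower the number relative to compound 1. The step expected for compound 4 is a 3.1-fold lower number from compound 1 to compound 4 (0.49 log units; beyond the scatter), smaller and less certain than the large measured steps. The estimate for compound 4 in this assay is 150 nM, with a range from 40 nM to 600 nM.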

Compound 4, half-maximal inhibitory concentration: 150 nM
Compound 4: middle estimate and measured number agree at the digits printed; the measured number falls inside the stated range.
By their numbers in this assay, from the lowest: compound 3; then compound 4; then compounds 1 and 2 (each within the scatter of the next).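

In this assay an aromatic ring on this saturated chain carbon goes with a lower number, seen in a 3.1-fold lower number from compound 1 to compound 4 (0.49 log units; beyond the scatter) and also in a 3.9-fold lower number from compound 2 to compound 4 (0.59 log units; beyond the scatter) against the group with cyclopropyl on the nitrogen. Cyclopentyl on the amine nitrogen still gives the lowest number of the set, with a 5.0-fold higher number from compound 3 to compound 4 (0.70 log units; beyond the scatter) separating the two groups. Both groups hold a five-membered ring, so ring size alone does not fix the number here, although (thiophen-3-yl)methyl also carries a chain carbon that cyclopentyl lacks.

As far as these compounds go, it stays open whether the sulfur-containing aromatic ring or the ring size matters more, which a cyclopentylmethyl or a benzyl group on the same nitrogen would help to separate. From the compounds shown here alone, it also stays open how thiophen-3-yl would behave placed on the nitrogen without its chain carbon. Nothing available explains why these numbers differ.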